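Compound 1 to compound 4: an aryl exchange

A few compounds are considered here, and "the series" means these few. Any claim that something is new, unique, unknown or untested is made for them only; others in the source may bear on it.

In a functional assay on MCF7 cells (Homo sapiens) for inhibition, read by sulforhodamine B assay, with a stated time of 48 h, tested at 50 uM (on this read-out higher numbers stand for more inhibition of growth at the one concentration tested and lower numbers for less inhibition of growth), compound 1 `COc1ccc([C@@H]2C/C(=N/OCc3cn(-c4cccc(CO)c4)nn3)c3cc(CC=C(C)C)c(OC)cc3O2)cc1` gives 42% as the lowest of the three numbers in hand. Compound 2 `CCOc1ccc([C@@H]2CC(=O)c3cc(CC=C(C)C)c(OC)cc3O2)cc1` gives 57% and compound 3 `C#CCOc1ccc([C@@H]2CC(=O)c3cc(CC=C(C)C)c(OC)cc3O2)cc1` gives 68% in this assay and both lie beyond the scatter from compound 1. Compound 4 `COc1ccc([C@@H]2C/C(=N/OCc3cn(-c4ccc(NC(C)=O)cc4)nn3)c3cc(CC=C(C)C)c(OC)cc3O2)cc1` keeps the core of compound 1 and carries 4-acetamidophenyl in place of 3-(hydroxymethyl)phenyl on an aromatic nitrogen of a five-membered aromatic ring with 3 nitrogen (4-acetamidophenyl in place of 3-(hydroxymethyl)phenyl on an aromatic nitrogen). Within the data shown here, no measured pair varies the group at this place. Among the measured compounds shown here, the only measured step is modest (a number 11 percentage points higher from compound 2 to compound 3 (beyond the scatter)) and concerns ethynyl in place of methyl elsewhere in the molecule, so it gives only a rough scale and no direction. A shift of no more than that modest size is therefore expected, and no clear direction can be assigned. The expected step is a number 3 percentage points higher from compound 1 to compound 4 (within the scatter) and it is not expected to exceed the scatter. In this assay compound 4 is estimated at 45% with an expected range of 30% to 60% for that number.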

Compound 4, percent growth inhibition at one concentration: 0%
For compound 4 the middle estimate is 45 percentage points above the measured one; the measured number lies below the stated range.
By their numbers in this assay, from the lowest: compound 4; then compound 1; then compound 2; then compound 3.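

In this assay the aryl group on the aromatic nitrogen is not a silent position: the exchange gives a number 42 percentage points lower from compound 1 to compound 4 (beyond the scatter), a large step where the only earlier one, a number 11 percentage points higher from compound 2 to compound 3 (beyond the scatter), was modest. The counts do not separate the two groups, as 3-(hydroxymethyl)phenyl and 4-acetamidophenyl each hold one six-membered aromatic ring, 1 hydrogen-bond donor and 1 hydrogen-bond acceptor, while the entering group has more heavy atoms and a double bond outside aromatic rings. No measurement at hand accounts for this step.

Still open, from the compounds shown here alone, is whether the step follows the acetamide itself or its place on the phenyl ring, since this single exchange alters both. A plain phenyl or a 4-aminophenyl at this position would be the nearest groups to set against 4-acetamidophenyl.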